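This account rests on a few compounds, and the source may have more. Where it says the series, first, only, none or still open, it means among the compounds named here.

Two cores are compared here. Compound 1 `C[C@H](NC(=O)c1c(C(F)(F)F)nnn1Cc1ccc(F)cc1)c1ccc(C(=O)O)cc1` and compound 2 `C[C@H](NC(=O)c1c(C(F)(F)F)nnn1Cc1ccc(C(F)(F)F)cc1)c1ccc(C(=O)O)cc1` share the first core, while compound 3 `C[C@H](NC(=O)c1c(-c2ccccc2)nnn1CCOc1ccc(F)cc1)c1ccc(C(=O)O)cc1` and compound 4 `C[C@H](NC(=O)c1c(-c2ccccc2)nnn1CCOc1ccc(C(F)(F)F)cc1)c1ccc(C(=O)O)cc1` share the second; how the two cores differ is not broken down here. In a functional assay on CHO cells for antagonist activity at prostaglandin E2 receptor EP4 subtype (Homo sapiens), read by calcium flux, with a stated time of 15 min (on this read-out higher numbers stand for weaker inhibition and lower numbers for stronger inhibition), compound 1 gives 2320 nM and compound 2 gives 225 nM, so the change trifluoromethyl in place of fluoro on an aromatic carbon brought a 10-fold lower number from compound 1 to compound 2 (1.01 log units; beyond the scatter). On the second core, compound 3 gives 3.1 nM in this assay, the lowest number of the three and beyond the scatter from both others. Compound 4 differs from compound 3 by trifluoromethyl in place of fluoro on an aromatic carbon, the same change at the same place. A step of a 3.1-fold lower number from compound 3 to compound 4 (0.49 log units; beyond the scatter) is expected, smaller than a 10-fold lower number from compound 1 to compound 2 (1.01 log units; beyond the scatter), because compound 3 already stands at 3.1 nM on a core whose difference from the first is not broken down here. Compound 4 is therefore estimated at 1 nM, within 0.3 nM to 4 nM.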

Compound 4, half-maximal inhibitory concentration: 49.1 nM
Compound 4: middle estimate off by 49-fold (1.69 log units), on the low side; the measured number lies above the stated range.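

On the core of compound 1, the exchange of fluoro for trifluoromethyl brought a 10-fold lower number from compound 1 to compound 2 (1.01 log units; beyond the scatter) in this assay, whereas on the core of compound 3 it brought a 16-fold higher number from compound 3 to compound 4 (1.20 log units; beyond the scatter). The two steps run in opposite directions, so the result of this change did not carry from one core to the other: the same change on two cores in this assay, a 10-fold lower number (1.01 log units; beyond the scatter) from compound 1 to compound 2 and a 16-fold higher number (1.20 log units; beyond the scatter) from compound 3 to compound 4, 160-fold (2.21 log units) apart, beyond the scatter of two such steps With one pair on each core, this does not show which feature of the cores sets the direction, nor how the change would behave on any further core.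

From the compounds shown here alone, it remains open which part of the difference between the two cores turns the step around. Also open, going by these compounds, is how a chloro or methoxy group at the same place would compare on each core.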